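The compounds below may be only part of what the source reports. "The series", "measured", "known", "first", "only" and "open" are said of these compounds alone.

Compound 3 `CCCC(=O)C1=C(C)NC(=O)NC1c1ccsc1` gives 6% in an assay on membranes from CHO cells for displacement of a labelled ligand from adenosine receptor A1 (Homo sapiens), read by scintillation counting, with a stated time of 60 min, tested at 1 uM (on this read-out lower numbers stand for less inhibition and higher numbers for more inhibition at the one concentration tested (going by the name of the read-out)), the second highest of the three numbers measured. Compound 2 `CCCC(=O)C1=C(C)NC(=O)NC1c1ccoc1` gives 1% in this assay. The step of a number 5 percentage points higher from compound 2 to compound 3 (within the scatter) stays within the scatter. Compound 1 `CCCOC(=O)C1=C(C)NC(=O)NC1c1ccsc1` gives 44% in this assay. The step of a number 38 percentage points lower from compound 1 to compound 3 (beyond the scatter) is the only one beyond the scatter. Compound 4 `CC1=C(C(N)=O)C(c2ccsc2)NC(=O)N1` carries amino in place of propyl on a carbonyl carbon. Going by the values given here, no measured step exchanges propyl for amino; the one step made on a carbonyl carbon, propoxy to propyl, was large and downward, yet compound 3 already sits near the floor, so little room remains to fall. The expected step is therefore a number 2 percentage points higher from compound 3 to compound 4 (within the scatter), within the scatter. Compound 4 is estimated at 8%, between 0% and 30%.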

Compound 4, a percentage reported as inhibition, at one concentration (the size of the read-out at that concentration, not a potency): 2%
Compound 4: middle estimate off by 6 percentage points, on the high side; the measured number falls inside the stated range.
By their numbers in this assay, from the lowest: compounds 2, 4 and 3 (each within the scatter of the next); then compound 1.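

On the carbonyl carbon, amino and propyl cannot be told apart in this assay: the exchange gives a number 4 percentage points lower from compound 3 to compound 4 (within the scatter). Amino in place of propoxy gives a number 42 percentage points lower from compound 1 to compound 4 (beyond the scatter), so among the groups shown at this place, two different replacements of propoxy, propyl and amino, both leave the number near that of compound 3 and well short of compound 1. Nothing available explains these numbers. From the compounds shown here alone, it remains open whether methoxy or butoxy at this place would keep the number of compound 1, and whether propylamino would behave like amino or like propoxy.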